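Adding 4-methoxyphenyl to a compound at the limit

The compounds below may be only part of what the source reports. "The series", "measured", "known", "first", "only" and "open" are said of these compounds alone.

Compound 1 `COc1ccc(S(=O)(=O)C2(C(=O)Nc3ccccc3N)CCC3(CCNCC3)C2)cc1Cl`: 7500 nM
Compound 2 `COc1ccc(Oc2ccc(S(=O)(=O)C3(C(=O)Nc4ccccc4N)CCC4(CCNCC4)C3)cc2Cl)cc1`: > 15000 nM (a limit)
Compound 3 `CNC(=O)NC(=O)C1(S(=O)(=O)c2ccc(OC)c(Cl)c2)CCC2(CCNCC2)C1`: > 15000 nM (a limit)

All three compounds were measured in a functional assay on blood (Homo sapiens), with a stated time of 60 min, in the presence of a further agent that is not named here; on this read-out lower numbers stand for an effect already at smaller amounts and higher numbers for an effect only at larger amounts of compound. Compound 3 stands at the limit of > 15000 nM in this assay, at which 2 of the 3 values shown sit, so it has a limit and no number. The change to compound 4 `CNC(=O)NC(=O)C1(S(=O)(=O)c2ccc(Oc3ccc(OC)cc3)c(Cl)c2)CCC2(CCNCC2)C1` is 4-methoxyphenyl in place of methyl on an oxygen on an aromatic ring. The same exchange appears in one measured step, an at least 2.0-fold higher number from compound 1 to compound 2 (0.30 log units; that floor lies within the scatter). The other measured step, an at least 2.0-fold higher number from compound 1 to compound 3 (0.30 log units; that floor lies within the scatter), is a different change and bears on the new one only by showing where compound 3 starts. Both sizes are floors resting on a limit, so neither gives a true size. No move toward a lower number is expected, and compound 4 is expected to stay at the limit of the assay. The estimated change is a step that the limit leaves unreadable from compound 3 to compound 4. For compound 4 the estimated value is 20000 nM, with an expected range from 10000 nM to 40000 nM.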

Compound 4, half-maximal effective concentration: 3700 nM
For compound 4 the middle estimate is 5.4-fold (0.73 log units) above the measured one, and the stated range ends above it.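

In this assay, 4-methoxyphenyl in place of methyl on an oxygen on an aromatic ring gives an at least 4.0-fold lower number from compound 3 to compound 4 (0.60 log units; beyond the scatter), so this position accepts the larger group when the amide-type nitrogen carries methylcarbamoyl. The same exchange does not act alike on the two cores, and what sits on that nitrogen decides its direction in these four compounds: the same change on two cores in this assay, an at least 2.0-fold higher number (0.30 log units; that floor lies within the scatter) from compound 1 to compound 2 and an at least 4.0-fold lower number (0.60 log units; beyond the scatter) from compound 3 to compound 4, at least 8.1-fold (0.90 log units) apart, beyond the scatter of two such steps. Read the other way, methylcarbamoyl in place of 2-aminophenyl gives an at least 4.0-fold lower number from compound 2 to compound 4 (0.60 log units; beyond the scatter), and that exchange also differs with the group on the oxygen: the same change on two cores in this assay, an at least 2.0-fold higher number (0.30 log units; that floor lies within the scatter) from compound 1 to compound 3 and an at least 4.0-fold lower number (0.60 log units; beyond the scatter) from compound 2 to compound 4, at least 8.1-fold (0.90 log units) apart, beyond the scatter of two such steps.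

On these data alone, the true sizes of these steps stay open, with compound 2 and compound 3 known only as limits: the limit of > 15000 nM in this assay, at which 2 of the 4 values shown sit. Also open, as far as these compounds go, is whether an amine or a carboxylic acid in place of the methoxy group of the 4-methoxyphenyl would keep or change the result seen for compound 4.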